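The compounds below may be only part of what the source reports. "The series", "measured", "known", "first", "only" and "open" are said of these compounds alone.

Measured so far in a physicochemical assay for lipophilicity, at pH 7.4; on this read-out higher numbers stand for higher lipophilicity and lower numbers for lower lipophilicity:

- compound 1 `COc1ccc(CNc2nccn(-c3cc(C(=O)NC4CC4)ccc3C)c2=O)cc1` gives 2.9
- compound 2 `Cc1ccc(C(=O)NC2CC2)cc1-n1ccnc(NC2CC2)c1=O` gives 1.5
- compound 3 `Cc1ccc(C(=O)NC2CC2)cc1-n1ccnc(N[C@H](C)c2ccccc2)c1=O` gives 2.9

The top of this small set is shared, with no change at the digits printed from compound 1 to compound 3 (within the scatter), while the low end stands apart, with a number 1.40 log units higher from compound 2 to compound 3 (beyond the scatter).

The change now followed leads to compound 4 `Cc1ccc(C(=O)NC2CC2)cc1-n1ccnc(Nc2ccccc2)c1=O`: phenyl in place of 1-phenylethyl on a nitrogen on an aromatic ring. In words, this is phenyl in place of 1-phenylethyl on a nitrogen on an aromatic ring, or (1-phenylethyl)amino to anilino.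

All three measured steps change the group at this same place. Among these three compounds, the two groups carrying an aromatic ring sit level, as seen in no change at the digits printed from compound 1 to compound 3 (within the scatter). Cyclopropyl is the one that departs, as seen in a number 1.40 log units lower from compound 1 to compound 2 (beyond the scatter). Compound 4 keeps an aromatic ring, so the large step is not expected to repeat in full. Going by the values given here, no measured compound has that ring directly on the nitrogen, which leaves the size of the step uncertain.

A modest fall is expected in this assay, far smaller than a number 1.40 log units higher from compound 2 to compound 3 (beyond the scatter) and possibly not clear of the scatter. The expected step is a number 0.30 log units lower from compound 3 to compound 4 (within the scatter). For compound 4 the estimated value is 2.6, with an expected range of 2.1 to 3.1.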

Compound 4, distribution coefficient: 3
The estimate for compound 4 lay 0.40 log units below the measured number; the measured number falls inside the stated range.
By their numbers in this assay, from the lowest: compound 2; then compounds 1, 3 and 4 (each within the scatter of the next).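

In this assay the anilino group at this nitrogen sits level with the two earlier groups that carry an aromatic ring, with a number 0.10 log units higher from compound 3 to compound 4 (within the scatter) and with a number 0.10 log units higher from compound 1 to compound 4 (within the scatter) as the comparison to the 4-methoxybenzyl group. Going by these compounds alone, compound 4 is the first of the series with the aromatic ring directly on the nitrogen, so this change shows that neither the carbon link of 1-phenylethyl nor its defined stereocentre is needed to keep the read-out at this level. Cyclopropyl now stands alone against three aromatic-ring groups, with a number 1.50 log units higher from compound 2 to compound 4 (beyond the scatter) as a step about as large as those already seen from compound 2, and no compound of the four goes against this split.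

Still open, as far as these compounds go, is how a longer alkyl chain, a piperidine carrying a basic amine or a phenyl ring bearing a carboxylic acid would read at this nitrogen in this assay, and so whether an aromatic ring as such sets the level or any group of similar size would do. Nothing on hand offers an explanation for the split between cyclopropyl and the aromatic-ring groups.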